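Methylphenyl to fluorophenyl on the triazole nitrogen

The source may hold more compounds than are shown below. What is called first, only, known or untested is meant among the compounds shown, and "the series" means these compounds.

Compound 3 `Cc1ccc(-n2cc(-c3cccc(NS(=O)(=O)c4c[nH]c(=O)[nH]c4=O)c3)nn2)cc1` gives 9430 nM in a functional assay on SGC-7901 cells (Homo sapiens) for antiproliferative activity, read by MTT assay, with a stated time of 24 h (a higher number here means a weaker inhibitor, a lower number a stronger inhibitor), within the scatter of compound 1 `Cc1ccccc1-n1cc(-c2cccc(NS(=O)(=O)c3c[nH]c(=O)[nH]c3=O)c2)nn1` at 9230 nM and of compound 2 `Cc1cccc(-n2cc(-c3cccc(NS(=O)(=O)c4c[nH]c(=O)[nH]c4=O)c3)nn2)c1` at 9100 nM. Compound 4 `O=c1[nH]cc(S(=O)(=O)Nc2cccc(-c3cn(-c4ccccc4F)nn3)c2)c(=O)[nH]1` carries 2-fluorophenyl in place of 4-methylphenyl on an aromatic nitrogen. The measured steps all move a methyl around the phenyl ring on that nitrogen: a 1.0-fold lower number from compound 1 to compound 2 (0.01 log units; within the scatter), a 1.0-fold higher number from compound 1 to compound 3 (0.01 log units; within the scatter) and a 1.0-fold higher number from compound 2 to compound 3 (0.02 log units; within the scatter), every one within the scatter. Going by the values given here, no measured step exchanges methyl for fluorine, so there is nothing to push the expectation away from the shared level, and no step beyond the scatter is expected in this assay. Compound 4 is therefore estimated at 9300 nM, range 4500 nM to 19000 nM, which is an expected step of a 1.0-fold lower number from compound 3 to compound 4 (0.01 log units; within the scatter).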

Compound 4, half-maximal inhibitory concentration: 16000 nM
Compound 4: middle estimate off by 1.7-fold (0.24 log units), on the low side, within the range that was stated.
By their numbers in this assay, from the lowest: compounds 2, 1, 3 and 4 (each within the scatter of the next).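

In this assay, fluoro in place of methyl leaves this substituent on the aromatic nitrogen within the scatter, with a 1.7-fold higher number from compound 1 to compound 4 (0.24 log units; within the scatter) for the direct exchange. The same holds for the two steps that also change the place on the phenyl ring: a 1.8-fold higher number from compound 2 to compound 4 (0.25 log units; within the scatter) and a 1.7-fold higher number from compound 3 to compound 4 (0.23 log units; within the scatter). This position therefore accepts 2-fluorophenyl as well as the three methylphenyl groups, and nothing available gives a cause for these steps. Still open, on these data alone, is whether any group here can produce a step beyond the scatter. A carboxylic acid or an amine on this phenyl ring would test that, as would a longer alkyl chain in place of the ring.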